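Saturated imidazolidinedione in place of the ylidene ring

This account rests on a few compounds, and the source may have more. Where it says the series, first, only, none or still open, it means among the compounds named here.

Measured compounds:
compound 1 `CC(C)C(/C=C1\NC(=O)NC1=O)c1ccc(-c2ccc3cccc(F)c3c2)[nH]c1=O`: 43 nM
compound 2 `C/C(=C1/OC(=O)NC1=O)C(c1ccc(-c2ccc3cccc(F)c3c2)[nH]c1=O)C(C)C`: 17 nM
compound 3 `CC(C)C(/C=C1\SC(=O)NC1=O)c1ccc(-c2ccc3cccc(F)c3c2)[nH]c1=O`: 13 nM

In an assay on membranes from Chem-1 cells for displacement of a labelled ligand from prostaglandin E2 receptor EP3 subtype (Homo sapiens), read by scintillation counting, with a stated time of 2 h (a lower number here means a stronger inhibitor, a higher number a weaker inhibitor), compound 3 gives the lowest number of the three. Against compound 2 the gap is within the scatter, so no order between these two is claimed; against compound 1 the difference is a 3.3-fold lower number from compound 1 to compound 3 (0.52 log units; beyond the scatter), which is beyond the scatter.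

Compound 4 `CC(C)C(c1ccc(-c2ccc3cccc(F)c3c2)[nH]c1=O)C1C(=O)NC(=O)N1C` differs from compound 3 by a group of 8 heavy atoms (4 carbon, 2 nitrogen, 2 oxygen; one five-membered non-aromatic ring with 2 hetero atoms) in place of a group of 8 heavy atoms (4 carbon, 1 nitrogen, 2 oxygen, 1 sulfur; one five-membered non-aromatic ring with 2 hetero atoms), on a saturated chain carbon bound to an aromatic carbon and a saturated chain carbon. The entering 3-methyl-2,5-dioxoimidazolidin-4-yl ring has two nitrogen atoms as in compound 1, but it sits on the chain carbon without the exocyclic double bond present in compounds 1, 2 and 3, and it carries a methyl on one nitrogen. Within the data shown here, the step of a 3.3-fold lower number from compound 1 to compound 3 (0.52 log units; beyond the scatter) bears on the return from a sulfur-containing ring to a two-nitrogen ring and points towards a higher number; no measured step covers the loss of the double bond or the added methyl. A step upward, at least of the size seen from compound 1 to compound 3, is therefore expected in this assay, written as a 4.6-fold higher number from compound 3 to compound 4 (0.66 log units; beyond the scatter). Compound 4 is estimated at 60 nM, with a range from 15 nM to 250 nM.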

Compound 4, inhibition constant: 46 nM
The estimate for compound 4 lay 1.3-fold (0.12 log units) above the measured number; the measured number falls inside the stated range.
By their numbers in this assay, from the lowest: compounds 3 and 2 (each within the scatter of the next); then compounds 1 and 4 (each within the scatter of the next).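

In this assay, the step of a 1.1-fold higher number from compound 1 to compound 4 (0.03 log units; within the scatter) is within the scatter, so the 3-methyl-2,5-dioxoimidazolidin-4-yl ring, lacking the exocyclic double bond, is not separated from the two-nitrogen ylidene ring of compound 1. The steps of a 3.5-fold higher number from compound 3 to compound 4 (0.55 log units; beyond the scatter) and a 2.7-fold higher number from compound 2 to compound 4 (0.43 log units; beyond the scatter) are beyond the scatter, and with compound 1 behaving the same way, both two-nitrogen rings give higher numbers than the rings of compounds 2 and 3, with no exception among these four compounds. No measurement at hand accounts for these steps.

On these data alone, compound 4 differs from compound 1 in both the double bond and the methyl on nitrogen, so their separate contributions, and whether they offset each other, remain open. Also open, as far as these compounds go, is what a carboxylic acid or an amine would give in place of the ring on this saturated chain carbon.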